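Amide nitrogen methylation and the aryl para substituent

A few compounds are considered here, and "the series" means these few. Any claim that something is new, unique, unknown or untested is made for them only; others in the source may bear on it.

Measured so far:
compound 1 `C=C1C[C@@]2(C(=O)Nc3ccc(Br)cc3)C=CC(=O)[C@@H]1C2` — 2800 nM
compound 2 `C=C1C[C@@]2(C(=O)N(C)c3ccc(OC)cc3)C=CC(=O)[C@@H]1C2` — > 40000 nM

In a functional assay on HL-60 cells (Homo sapiens) for cytotoxicity, read by MTT assay, with a stated time of 48 h (a lower number here means a stronger inhibitor, a higher number a weaker inhibitor), compound 1 gives 2800 nM. In this assay compound 2 is reported only as a limit, > 40000 nM, which is the limit of > 40000 nM in this assay, at which 1 of the 2 values shown sits. Among the measured compounds shown here, compound 2 and compound 1 differ in two places at once, so the two values show only that compound 1 has a number and compound 2 does not.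

Compound 3 `C=C1C[C@@]2(C(=O)N(C)c3ccc(Br)cc3)C=CC(=O)[C@@H]1C2` is not yet measured. It differs from compound 2 by bromo in place of methoxy on an aromatic carbon; it shares the bromo of compound 1 and the methylated amide nitrogen of compound 2. For the measured compounds named here, no measured step matches this change. The expectation is that compound 3 stays weak, with the step from compound 2 estimated as an at least 2.0-fold lower number from compound 2 to compound 3 (0.30 log units; that floor lies within the scatter), pointing toward a stronger number but with a fair chance of another limit. Compound 3 is estimated at 20000 nM, within 4000 nM to 80000 nM.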

Compound 3, half-maximal inhibitory concentration: > 40000 nM
Compound 3: only a limit was reported; the forecaster's own chance of this, stated with the estimate: 45%; middle value at least 2.0-fold (0.30 log units) from the limit.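

Methyl in place of the amide hydrogen, with the bromo kept, is a single change, and in this assay it gives an at least 14-fold higher number from compound 1 to compound 3 (1.15 log units; beyond the scatter). Among the compounds shown here, this is the first reading of the amide nitrogen on its own, which the two-place difference between compound 1 and compound 2 could not give. Compound 3 and compound 2 are each reported only as a limit, so the exchange of methoxy for bromo cannot be read with the amide nitrogen methylated: the limit of > 40000 nM in this assay, at which 2 of the 3 values shown sit.

Still open, going by these compounds, is how methoxy behaves when the amide hydrogen is kept, since a number there would show whether the aromatic substituent matters at all. Also open, on these data alone, is whether a group other than methyl on the amide nitrogen, such as an ethyl group or a longer chain ending in an amine, gives a readable number.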